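A few compounds are considered here, and "the series" means these few. Any claim that something is new, unique, unknown or untested is made for them only; others in the source may bear on it.

In an assay for inhibition of transmembrane protease serine 4 (Homo sapiens), read by fluorescence (on this read-out lower numbers stand for stronger inhibition and higher numbers for weaker inhibition), the measured compounds stand as follows: compound 1 `COc1cc(NC(=O)c2cc(Cl)ccc2O)cc(C(F)(F)F)c1` gives 16000 nM; compound 2 `O=C(Nc1cc(Br)cc(C(F)(F)F)c1)c1cc(Cl)ccc1O` gives 12000 nM; compound 3 `O=C(Nc1cc(C(F)(F)F)ccc1F)c1cc(Cl)ccc1O` gives 28000 nM.

Compound 3 gives the highest of the three numbers. Its nearest neighbour is compound 1, a gap within the scatter; the gap to compound 2 lies beyond the scatter. Compound 4 `O=C(Nc1cccc(C(F)(F)F)c1)c1cc(Cl)ccc1O` differs from compound 3 by hydrogen in place of fluoro on an aromatic carbon. For the measured compounds named here, the only measured single-place step is a 1.3-fold lower number from compound 1 to compound 2 (0.12 log units; within the scatter), an exchange of one substituent for another on the same ring, which stayed within the scatter. Going by the values given here, no measured step removes a fluoro, so nothing bears directly on this change; no move beyond the scatter is expected in this assay, with a slight lean toward the numbers of compound 1 and compound 2. Compound 4 is estimated at 18000 nM, range 7000 nM to 45000 nM. This means an expected step of a 1.6-fold lower number from compound 3 to compound 4 (0.19 log units; within the scatter).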

Compound 4, half-maximal inhibitory concentration: 13000 nM
For compound 4 the middle estimate is 1.4-fold (0.14 log units) above the measured one; the range from low to high includes it.
By their numbers in this assay, from the lowest: compounds 2, 4, 1 and 3 (each within the scatter of the next, the first and the last beyond it).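

In this assay, for the compounds shown here, the fluoro ortho to a large group and para to a trifluoromethyl group matters: hydrogen in its place gives a 2.2-fold lower number from compound 3 to compound 4 (0.33 log units; beyond the scatter), the only single-place change so far beyond the scatter. Hydrogen in place of bromo gives a 1.1-fold higher number from compound 2 to compound 4 (0.03 log units; within the scatter) and hydrogen in place of methoxy gives a 1.2-fold lower number from compound 1 to compound 4 (0.09 log units; within the scatter), so neither group stands apart from hydrogen. No evidence at hand accounts for the fluoro step. From the compounds shown here alone, whether an amine or a carboxylic acid at the fluoro position would stay level with compound 4 remains open.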